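A few compounds are considered here, and "the series" means these few. Any claim that something is new, unique, unknown or untested is made for them only; others in the source may bear on it.

Measured compounds:
Compound 1, `CC(C)N(Cc1cccc(OCCCCCC(=O)O)c1)C(=O)c1ccc(-c2cccc3ccccc23)cc1`, < 1.3 nM
Compound 2, `CC(C)N(Cc1cccc(OCCCCCC(=O)O)c1)C(=O)c1ccc(-c2cccc(Oc3ccccc3)c2)cc1`, > 18700 nM
Compound 3, `CC(C)N(Cc1cccc(OCCCCCC(=O)O)c1)C(=O)c1ccc(-c2cc3ccccc3n2S(=O)(=O)c2ccccc2)cc1`, > 26000 nM

The three compounds share one core and differ only in the aryl group at its far end. In an ADME assay on BJ cells (Homo sapiens) for cytotoxicity, read by CellTiter-Glo and resazurin assay, with a stated time of 72 h (a higher number here means that more compound is needed for the effect, a lower number that less compound is needed), compound 1 reaches a limit of the assay, < 1.3 nM, which is the limit of < 1.3 nM in this assay, at which 1 of the 3 values shown sits. Compound 2 gives only a limit in this assay, > 18700 nM, which is the limit of > 18700 nM in this assay, at which 1 of the 3 values shown sits. Compound 3 likewise gives only a limit, > 26000 nM, which is the limit of > 26000 nM in this assay, at which 1 of the 3 values shown sits. So compound 2 stands at an upper limit, and no number is known for it; the two other values shown are limits as well, one at the low end and one at the high end, so no measured step between two numbers exists in this set.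

Compound 4, `CC(C)N(Cc1cccc(OCCCCCC(=O)O)c1)C(=O)c1ccc(-c2cccc(F)c2)cc1`, has not yet been measured in this assay. It differs from compound 2 in one place: fluoro in place of phenoxy on an aromatic carbon. Since compound 2 has only a limit, the size of the step cannot be fixed against a number; any move beyond the scatter would have to go downward, toward the value seen for compound 1, and whether it does is open. Compound 4 is expected to give about 9000 nM, within 1500 nM to 30000 nM, which would mean an estimated step of an at least 2.0-fold lower number from compound 2 to compound 4 (0.31 log units; beyond the scatter).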

Compound 4, half-maximal effective concentration: > 26000 nM
Compound 4 was reported as a limit; the forecaster's own chance of this, stated with the estimate: 45%; at least 2.8-fold (0.46 log units) between middle value and limit.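

Compound 4 shows that the phenoxy group, with its six-membered aromatic ring of carbon only, is not needed for a compound to reach the high end of this assay: with a lone fluoro in its place, meta to a large group, the reading still does not come down to a number. Compound 4 stands at a limit of the assay, not at a measured value: the limit of > 26000 nM in this assay, at which 2 of the 4 values shown sit. The change to 3-fluorophenyl in place of naphthalen-1-yl gives an at least 20000-fold higher number from compound 1 to compound 4 (4.30 log units; beyond the scatter), so among the four compounds only compound 1 stands at the low end, while the step between the limits of compound 2 and compound 4 cannot be read.

The compounds shown leave open whether the low value of compound 1 needs the whole naphthalen-1-yl group, or whether a naphthalen-2-yl or a plain phenyl group at that place would keep it. They also leave open whether an amine or a nitrile in place of the fluoro would bring the reading down to a number that could be compared.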